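Aryl urea variation on a shared thienopyrimidine-type series

The source may report more compounds than this note shows. Statements on the series, on what has been measured and on what is new or still open speak of the compounds shown alone.

Three measured compounds share one core and differ only in the aryl group on the urea nitrogen. Compound 1 `O=C(Nc1cccc(Cl)c1)Nc1nnc(Sc2ncnc3scc(-c4ccncc4)c23)s1` carries a 3-chlorophenyl there and in a functional assay on HUVEC cells (Homo sapiens) for antiproliferative activity, read by MTT assay, with a stated time of 48 h (on this read-out lower numbers stand for stronger inhibition and higher numbers for weaker inhibition), compound 1 gives 21000 nM. Compound 2 `Cc1ccc(NC(=O)Nc2nnc(Sc3ncnc4scc(-c5ccncc5)c34)s2)cc1` carries a 4-methylphenyl and in this assay compound 2 gives 19300 nM. Compound 3 `O=C(Nc1ccc(F)cc1)Nc1nnc(Sc2ncnc3scc(-c4ccncc4)c23)s1` carries a 4-fluorophenyl and in this assay compound 3 gives 28300 nM, the highest of the three numbers; the differences to the other two, a 1.3-fold higher number from compound 1 to compound 3 (0.13 log units; within the scatter) and a 1.5-fold higher number from compound 2 to compound 3 (0.17 log units; within the scatter), both lie within the scatter, so no ordering among the three can be claimed.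

Compound 4 `COc1cccc(NC(=O)Nc2nnc(Sc3ncnc4scc(-c5ccncc5)c34)s2)c1` is not yet measured. Its change against compound 3 is 3-methoxyphenyl in place of 4-fluorophenyl on an amide-type nitrogen. Within the data shown here, the steps that bear on it are the aryl swaps already seen: a 1.1-fold lower number from compound 1 to compound 2 (0.04 log units; within the scatter) and a 1.3-fold higher number from compound 1 to compound 3 (0.13 log units; within the scatter), each within the scatter. On that basis the aryl group on the urea nitrogen has so far left this assay unchanged, and no step beyond the scatter is expected here either; the expected step is a 1.3-fold lower number from compound 3 to compound 4 (0.11 log units; within the scatter). For compound 4 in this assay the estimate is 22000 nM, with a range from 11000 nM to 45000 nM.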

Compound 4, half-maximal inhibitory concentration: 67700 nM
Beside the measured number, compound 4's estimate is 3.1-fold (0.49 log units) below it; measured number outside the range, above it.
By their numbers in this assay, from the lowest: compounds 2, 1 and 3 (each within the scatter of the next); then compound 4.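

Notes on the aryl group at the urea nitrogen: this position is not silent in this assay, since 3-methoxyphenyl gives the first steps here beyond the scatter, with a 2.4-fold higher number from compound 3 to compound 4 (0.38 log units; beyond the scatter) and a 3.5-fold higher number from compound 2 to compound 4 (0.55 log units; beyond the scatter) and a 3.2-fold higher number from compound 1 to compound 4 (0.51 log units; beyond the scatter) as the three readings of the change. All three steps are modest and run the same way, so compound 4 separates from the other three aryl ureas, which remain within the scatter of each other. The pair of compound 1 and compound 4 differs only by methoxy in place of chloro on an aromatic carbon, so a change of that single substituent is enough to give a step of this size.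

No measurement in hand gives a reason for this shift.

Open, as far as these compounds go, is whether the higher number belongs to methoxy alone or would also appear with a hydroxy, ethoxy or dimethylamino group on the same phenyl ring. Also open is whether any group at this nitrogen, such as a pyridyl ring, an aminophenyl or a carboxyphenyl, would move the number in the opposite direction, as the compounds shown contain no step toward a lower number beyond the scatter.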